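Two halogens traded on the ring nitrogen

The source may report more compounds than this note shows. Statements on the series, on what has been measured and on what is new or still open speak of the compounds shown alone.

Within the data shown here, compound 2 `CCCCCCCC/C=C\CCCCCCCC1=NN(c2ccc(F)cc2F)C(=O)C1` gives 5000 nM in an assay on microsomes from intestine for inhibition of acyl-CoA:cholesterol acyltransferase (Oryctolagus cuniculus) (a lower number here means a stronger inhibitor, a higher number a weaker inhibitor), the lower of the two numbers measured so far. Compound 1 `Cc1cccc(C)c1N1N=C(CC(c2ccccc2)c2ccccc2)CC1=O`, built on a different core, gives 50800 nM in this assay, so its number stands well above that of compound 2, beyond the usual scatter of repeated measurements. Compound 3 `CCCCCCCC/C=C\CCCCCCCC1=NN(c2ccc(Cl)cc2Cl)C(=O)C1` has not yet been measured; it differs from compound 2 in a single place: 2,4-dichlorophenyl in place of 2,4-difluorophenyl on an amide-type nitrogen in a ring. Among the measured compounds shown here, no measured pair in this set exchanges one halogen for another, so nothing here shows how large such a step tends to be. The step of a 1.7-fold lower number from compound 2 to compound 3 (0.22 log units; within the scatter) is therefore expected to be small, leaning toward a somewhat lower number but quite possibly within the scatter. In this assay compound 3 is estimated at 3000 nM, with a range from 1000 nM to 10000 nM.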

Compound 3, half-maximal inhibitory concentration: 9900 nM
The estimate for compound 3 lay 3.3-fold (0.52 log units) below the measured number, and the stated range covers the measured number.
By their numbers in this assay, from the lowest: compounds 2 and 3 (each within the scatter of the next); then compound 1.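

In this assay, among these compounds, replacing 2,4-difluorophenyl with 2,4-dichlorophenyl on the amide-type nitrogen gives a 2.0-fold higher number from compound 2 to compound 3 (0.30 log units; within the scatter) and provides the first reading of a halogen-for-halogen exchange in this set. On the shared core, with the long unsaturated chain left unchanged, this assay does not separate these two halogen pairs, so this single comparison gives no sign that fluorine and chlorine differ at this position. Nothing measured here offers an explanation for the size of this step.

As far as these compounds go, both halogens change together, so the contribution of each one alone remains unknown. Also open, from the compounds shown here alone, is how this assay would respond to a plain phenyl ring, a methoxy group or an amine on this ring, any of which would test the position more broadly than one halogen exchanged for another.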